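The compounds below may be only part of what the source reports. "The series", "measured", "known", "first", "only" and "open" are said of these compounds alone.

Compound 1 `C=C1[C@@H](OC(C)=O)C[C@@H]2[C@](C)(CO[Si](C)(C)C(C)(C)C)[C@H](OC(C)=O)CC[C@@]2(C)[C@@H]1C[C@@H](Nc1ccccc1)C1=CCOC1=O` gives 4500 nM in a functional assay on A549 cells (Homo sapiens) for cytotoxicity, read by sulforhodamine B assay; a higher number here means a weaker inhibitor, a lower number a stronger inhibitor. Compound 2 `C=C1[C@@H](OC(C)=O)C[C@@H]2[C@](C)(COC=O)[C@H](OC(C)=O)CC[C@@]2(C)[C@@H]1C[C@@H](Nc1ccc(Br)cc1)C1=CCOC1=O` gives 15900 nM. Compound 3 `C=C1[C@@H](OC(C)=O)C[C@@H]2[C@](C)(CO[Si](C)(C)C(C)(C)C)[C@H](OC(C)=O)CC[C@@]2(C)[C@@H]1C[C@@H](Nc1ccc(Br)cc1)C1=CCOC1=O` gives 4150 nM.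

Compound 2 stands highest of the three numbers; its nearest neighbour is compound 1, and the step of a 3.8-fold lower number from compound 2 to compound 3 (0.58 log units; beyond the scatter) is the only one beyond the scatter that involves it. Compound 4 `C=C1[C@@H](OC(C)=O)C[C@@H]2[C@](C)(COC=O)[C@H](OC(C)=O)CC[C@@]2(C)[C@@H]1C[C@@H](Nc1ccc(F)cc1)C1=CCOC1=O` differs from compound 2 by fluoro in place of bromo on an aromatic carbon. Among the compounds with values here, the one measured step at the same place, a 1.1-fold lower number from compound 1 to compound 3 (0.04 log units; within the scatter), stayed within the scatter, so swapping one halogen for another on that aromatic carbon is not expected to matter much. The step of a 1.1-fold lower number from compound 2 to compound 4 (0.06 log units; within the scatter) is therefore expected to fall within the scatter. Compound 4 is estimated at 14000 nM, with a range from 6000 nM to 35000 nM.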

Compound 4, half-maximal inhibitory concentration: 21300 nM
The estimate for compound 4 lay 1.5-fold (0.18 log units) below the measured number; the measured number falls inside the stated range.
By their numbers in this assay, from the lowest: compounds 3 and 1 (each within the scatter of the next); then compounds 2 and 4 (each within the scatter of the next).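

In this assay, the exchange of 4-bromophenyl for 4-fluorophenyl gives a 1.3-fold higher number from compound 2 to compound 4 (0.13 log units; within the scatter), so one halogen can replace the other on this aromatic carbon without a change beyond the scatter. The earlier step at this position, a 1.1-fold lower number from compound 1 to compound 3 (0.04 log units; within the scatter), replaced hydrogen with bromo and carried the silyl ether, whereas this step replaces a halogen and carries the formate ester. No available evidence bears on this result. From the compounds shown here alone, whether an amine, a carboxylic acid or a methoxy group on this carbon would leave the number similarly unmoved remains open.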